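The source may report more compounds than this note shows. Statements on the series, on what has been measured and on what is new or still open speak of the compounds shown alone.

Measured in a functional assay for inhibition, with Homo sapiens as the target; on this read-out lower numbers stand for tighter binding and higher numbers for weaker binding:
- compound 1 `O=C(O)CC/C=C\CC1COC(c2ccc([N+](=O)[O-])cc2)OC1c1cccnc1`: 933 nM
- compound 2 `O=C(O)CC/C=C\CC1COC(c2cccc3ccccc23)OC1c1cccnc1`: 631 nM
- compound 3 `COc1ccc(OC(C)(C)C2OCC(C/C=C\CCC(=O)O)C(c3cccnc3)O2)cc1`: 302 nM

Compound 3 holds the lowest number of the three, and its gap to each of the other two lies beyond the scatter. Its value of 302 nM therefore marks the tightest binding seen so far in this assay.

The next compound to be considered is compound 4 `CC(C)(Oc1ccccc1O)C1OCC(C/C=C\CCC(=O)O)C(c2cccnc2)O1`, which has not yet been measured. It differs from compound 3 in one place: 2-hydroxyphenyl in place of 4-methoxyphenyl on an oxygen on a saturated carbon. In words, 2-hydroxyphenyl stands in place of 4-methoxyphenyl on an oxygen on a saturated carbon.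

Among the measured compounds shown here, no measured step covers this change. For the measured compounds named here, the only step available is a 1.5-fold lower number from compound 1 to compound 2 (0.17 log units; within the scatter), which replaces 4-nitrophenyl with naphthalen-1-yl on a saturated ring carbon. That is a different exchange at a different place, so it offers only weak guidance. It does show that one large aromatic exchange left the number within the scatter, and nothing in the data points to a large shift here.

The expected change is small, an estimated 1.5-fold lower number from compound 3 to compound 4 (0.18 log units; within the scatter), and it is not expected to exceed the scatter. For compound 4 the estimate in this assay is 200 nM, with an expected range of 60 nM to 700 nM.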

Compound 4, dissociation constant: 95.5 nM
Compound 4: the middle estimate sits 2.1-fold (0.32 log units) above what was measured, and the stated range covers the measured number.
By their numbers in this assay, from the lowest: compound 4; then compound 3; then compounds 2 and 1 (each within the scatter of the next).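

In this assay, among the compounds shown here, the exchange at this position gives a 3.2-fold lower number from compound 3 to compound 4 (0.50 log units; beyond the scatter), whereas the only earlier step, a 1.5-fold lower number from compound 1 to compound 2 (0.17 log units; within the scatter), involved a different place and stayed within the scatter. For the compounds shown here, this is therefore the first single exchange in the set to move the number beyond the scatter, and it shows that the aryl group on an oxygen on a saturated carbon can shift the read-out measurably, with compound 4 now holding the lowest number of the four. The entering 2-hydroxyphenyl carries a hydrogen-bond donor that the leaving 4-methoxyphenyl lacks, but the two groups also differ in the numbered place of their substituent, so the step cannot separate these differences, and no evidence is available to explain the lower number.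

The compounds shown leave open whether 4-hydroxyphenyl or 2-methoxyphenyl on this oxygen would tell the effect of the substituent from that of its place. They also leave open whether 2-aminophenyl, which carries an amine in place of the hydroxyl, would give a number like that of compound 4.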